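Swapping the chain amine in a quinoline ether amide series

The source may hold more compounds than are shown below. What is called first, only, known or untested is meant among the compounds shown, and "the series" means these compounds.

Measured compounds:
compound 1 `COc1cc2c(Oc3ccc(NC(=O)c4nn(-c5ccccc5)c(=O)cc4C)cc3F)ccnc2cc1OCCCN1CCN(C)CC1` gives 130 nM
compound 2 `COc1cc2c(Oc3ccc(NC(=O)c4nn(-c5ccccc5C)c(=O)cc4C)cc3F)ccnc2cc1OCCCN1CCN(C)CC1` gives 1630 nM
compound 3 `COc1cc2c(Oc3ccc(NC(=O)c4nn(-c5ccc(Cl)cc5)c(=O)cc4C)cc3F)ccnc2cc1OCCCN1CCC(C)CC1` gives 150 nM

In a functional assay on MKN-45 cells (Homo sapiens) for inhibition, read by MTT assay, with a stated time of 72 h (a higher number here means a weaker inhibitor, a lower number a stronger inhibitor), compound 3 stands second highest of the three numbers. Its nearest neighbour is compound 1, whose value lies within the scatter of that of compound 3; its furthest is compound 2, a gap beyond the scatter. Among the measured compounds shown here, the one step computed so far, a 13-fold higher number from compound 1 to compound 2 (1.10 log units; beyond the scatter), concerns a change on the aromatic ring of the pyridazinone substituent and does not touch the chain amine.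

Compound 4 `COc1cc2c(Oc3ccc(NC(=O)c4nn(-c5ccc(Cl)cc5)c(=O)cc4C)cc3F)ccnc2cc1OCCCN1CCN(C)CC1` differs from compound 3 in one place: 4-methylpiperazin-1-yl in place of 4-methylpiperidin-1-yl on a saturated chain carbon, three bonds along the chain from an oxygen on an aromatic ring. For the measured compounds named here, no measured step bears directly on this change. What can be said is that compound 1, which carries the same 4-methylpiperazin-1-yl group but a different aryl substituent, and compound 3 give values within the scatter of each other, so the two changes taken together did little in this assay. On that basis the step from compound 3 to compound 4 is expected to be small, a 1.1-fold lower number from compound 3 to compound 4 (0.03 log units; within the scatter), with no clear direction. The estimate for compound 4 is 140 nM, expected to fall between 60 nM and 330 nM.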

Compound 4, half-maximal inhibitory concentration: 40 nM
Compound 4: the middle estimate sits 3.5-fold (0.54 log units) above what was measured, outside the stated range (below it).
By their numbers in this assay, from the lowest: compound 4; then compounds 1 and 3 (each within the scatter of the next); then compound 2.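

In this assay, the chain amine matters at this place, on a saturated chain carbon, three bonds along the chain from an oxygen on an aromatic ring: 4-methylpiperazin-1-yl in place of 4-methylpiperidin-1-yl gives a 3.8-fold lower number from compound 3 to compound 4 (0.57 log units; beyond the scatter). With 4-methylpiperazin-1-yl held fixed, the group on the aromatic nitrogen also counts, as adding a chloro to the phenyl group gives a 3.3-fold lower number from compound 1 to compound 4 (0.51 log units; beyond the scatter), and 4-chlorophenyl in place of 2-methylphenyl gives a 41-fold lower number from compound 2 to compound 4 (1.61 log units; beyond the scatter). Nothing measured here accounts for any of these steps.

From the compounds shown here alone, it remains open whether a morpholin-4-yl group or a longer chain than the propyl would match 4-methylpiperazin-1-yl. Going by these compounds, it is equally open whether the step between the two chain amines has the same size when the chloro is replaced by fluoro or methoxy.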